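Halogen swap at the indole-type core in a thioether series

The source may report more compounds than this note shows. Statements on the series, on what has been measured and on what is new or still open speak of the compounds shown alone.

Measured compounds:
compound 1, `COc1ccccc1Sc1c[nH]c2ccc(Cl)cc12`, 17500 nM
compound 2, `COc1ccc(Sc2c[nH]c3ccc(Cl)cc23)cc1`, 16000 nM
compound 3, `COc1ccccc1Sc1c[nH]c2ccc(F)cc12`, 32000 nM

Three compounds share a core with a methoxyphenyl thioether and differ in the halogen or the position of the methoxy group. In an assay on isolated protein for inhibition of Indoleamine 2,3-dioxygenase 1 (Homo sapiens), read by HPLC, with a stated time of 60 min, in the presence of a further agent that is not named here (on this read-out higher numbers stand for weaker inhibition and lower numbers for stronger inhibition), compound 3 stands at the highest of the three numbers, but its nearest neighbour compound 1 and the furthest compound 2 both lie within the scatter of it, so no ordering among the three can be claimed.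

The step to the unmeasured compound 4, `COc1ccccc1Sc1c[nH]c2ccc(Br)cc12`, is bromo in place of fluoro on an aromatic carbon. For the measured compounds named here, only one measured step bears on it: a 1.8-fold higher number from compound 1 to compound 3 (0.26 log units; within the scatter), a change of one halogen for another at the same carbon that stayed within the scatter. Going by the values given here, the move from fluoro to bromo is a change of the same kind, and nothing among the measured compounds points to a larger effect. A step in this assay of about the size seen for compound 1 against compound 3 is therefore expected, most likely toward a somewhat lower number, though a flat result would be no surprise.

The estimate for compound 4 is accordingly 16000 nM, with a range from 6000 nM to 40000 nM, meaning an expected step of a 2.0-fold lower number from compound 3 to compound 4 (0.30 log units; within the scatter).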

Compound 4, half-maximal inhibitory concentration: 24000 nM
Estimate against measurement, compound 4: 1.5-fold (0.18 log units) below; measured number inside the range.
By their numbers in this assay, from the lowest: compounds 2, 1, 4 and 3 (each within the scatter of the next).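

In this assay, bromo in place of fluoro on an aromatic carbon gives a 1.3-fold lower number from compound 3 to compound 4 (0.12 log units; within the scatter) and bromo in place of chloro at that same carbon gives a 1.4-fold higher number from compound 1 to compound 4 (0.14 log units; within the scatter) and neither step leaves the scatter. The earlier compounds shown here offered a single halogen exchange at this carbon, whereas compound 1, compound 3 and compound 4 now cover fluoro, chloro and bromo, and all the steps among them are within the scatter, so this assay separates none of the three halogens at this position. The data shown contain no measurement that could explain this flat response.

The compounds shown carry only halogens at this carbon, so it remains open whether a plain hydrogen, a nitrile, an amine or a carboxylic acid there would give a step beyond the scatter. Also open is whether the same flat response to fluoro, chloro and bromo holds with the methoxy group placed as in compound 2, where only the chloro member is shown.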